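Replacing 5-bromopyridin-3-yl with 6-methylpyridin-3-yl in compound 4

The source may hold more compounds than are shown below. What is called first, only, known or untested is meant among the compounds shown, and "the series" means these compounds.

Compound 1 `Nc1ccccc1NC(=O)c1ccc(NC(=S)NCc2ccccc2F)cc1` gives 5400 nM in a functional assay on HepG2 cells (Homo sapiens) for cytotoxicity, read by MTT assay, with a stated time of 72 h; on this read-out lower numbers stand for stronger inhibition and higher numbers for weaker inhibition
Compound 2 `Nc1ccccc1NC(=O)c1ccc(NC(=S)NCc2cncc(F)c2)cc1` gives 13000 nM in this assay
Compound 3 `Nc1ccccc1NC(=O)c1ccc(NC(=S)NCc2cncc(Br)c2)cc1` gives 7500 nM in this assay

The account follows compound 3 as it is changed into compound 4 `Cc1ccc(CNC(=S)Nc2ccc(C(=O)Nc3ccccc3N)cc2)cn1`, which has not yet been measured. The measured gaps of a 1.4-fold higher number from compound 1 to compound 3 (0.14 log units; within the scatter) and a 1.7-fold lower number from compound 2 to compound 3 (0.24 log units; within the scatter) leave compound 3 within the scatter of both other compounds. In compound 4, 6-methylpyridin-3-yl stands in place of 5-bromopyridin-3-yl on a saturated chain carbon bound to an amide-type nitrogen, a difference that counts as 6-methylpyridin-3-yl in place of 5-bromopyridin-3-yl on a saturated chain carbon bound to an amide-type nitrogen in full. Going by the values given here, no measured step introduces this methyl group, so the evidence is only indirect. Among the compounds with values here, the only step beyond the scatter is the modest 2.4-fold higher number from compound 1 to compound 2 (0.38 log units; beyond the scatter) on exchanging 2-fluorophenyl for 5-fluoropyridin-3-yl. The two steps that reach compound 3 stay within the scatter, so changes at this position have moved the numbers little so far. No step beyond the scatter is therefore expected in this assay for this exchange. The expected move is a 1.2-fold higher number from compound 3 to compound 4 (0.08 log units; within the scatter) and points only weakly upward. For compound 4 the estimated value is 9000 nM with an expected range from 4500 nM to 18000 nM in this read-out.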

Compound 4, half-maximal inhibitory concentration: 11000 nM
Estimate against measurement, compound 4: 1.2-fold (0.09 log units) below; the range from low to high includes it.
By their numbers in this assay, from the lowest: compounds 1, 3, 4 and 2 (each within the scatter of the next, the first and the last beyond it).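

In this assay, exchanging 5-bromopyridin-3-yl for 6-methylpyridin-3-yl gives a 1.5-fold higher number from compound 3 to compound 4 (0.17 log units; within the scatter), and exchanging 5-fluoropyridin-3-yl for the same group gives a 1.2-fold lower number from compound 2 to compound 4 (0.07 log units; within the scatter), so a methyl-bearing pyridine now stands within the scatter of both halogen-bearing pyridines, and this position has tolerated a group without a halogen as well as those with one. The exchange of 2-fluorophenyl for 6-methylpyridin-3-yl gives a 2.0-fold higher number from compound 1 to compound 4 (0.31 log units; beyond the scatter), a second modest step beyond the scatter from the 2-fluorophenyl compound to a pyridine, although compound 3 goes against this pattern with a 1.4-fold higher number from compound 1 to compound 3 (0.14 log units; within the scatter). Nothing available accounts for these small differences among the four compounds.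

The compounds shown carry only a fluoro, bromo or methyl substituent on the pyridine, which leaves open whether a dimethylamino group or a carboxylic acid in that place would produce a larger step in this assay. They also leave open whether an unsubstituted pyridin-3-yl would stay within the scatter of compound 4, and whether a longer chain in place of the methyl of 6-methylpyridin-3-yl would do so.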